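A Methoxy Step Tested on a Second Core

A few compounds are considered here, and "the series" means these few. Any claim that something is new, unique, unknown or untested is made for them only; others in the source may bear on it.

Compound 1 `Cc1noc(C)c1Cn1cc(NC(=O)c2ccccc2)cn1` is the simplest member of the set. In a functional assay on cells for antagonist activity at taste receptor type 2 member 8 (Homo sapiens), read by FLIPR and calcium flux, with a stated time of 100 s (a lower number here means a stronger inhibitor, a higher number a weaker inhibitor), compound 1 gives 1700 nM. Compound 2 `COc1cccc(C(=O)Nc2cnn(Cc3c(C)noc3C)c2)c1` differs from it by methoxy in place of hydrogen on an aromatic carbon. In this assay compound 2 gives 700 nM, and the step from the parent is a 2.4-fold lower number from compound 1 to compound 2 (0.39 log units; beyond the scatter).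

Compound 3 `Cc1noc(C)c1Cn1cc(N2C(=O)CN(Cc3ccccc3)C2=O)cn1` is built on a different core; the difference between the cores of compound 1 and compound 3 is not broken down here. In this assay compound 3 gives 200 nM, the lowest of the three numbers, with both of its steps to the other compounds beyond the scatter.

Compound 4 `COc1ccccc1CN1CC(=O)N(c2cnn(Cc3c(C)noc3C)c2)C1=O` has not yet been measured. It differs from compound 3 by methoxy in place of hydrogen on an aromatic carbon. Among the compounds with values here, this is the same kind of change as the one from compound 1 to compound 2, but not the same change: in compound 2 the methoxy sits meta to a large group, in compound 4 it sits ortho to a large group, and the two cores differ as well.

Within the data shown here, the earlier step from compound 1 to compound 2 in this assay, a 2.4-fold lower number from compound 1 to compound 2 (0.39 log units; beyond the scatter), is the only guide, and its place and core are not those of compound 4, so a smaller step is expected, a 1.3-fold lower number from compound 3 to compound 4 (0.12 log units; within the scatter). Compound 4 is therefore estimated at 150 nM in this assay, expected to fall between 50 nM and 500 nM.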

Compound 4, half-maximal inhibitory concentration in the taste receptor type 2 member 8 assay: 100 nM
Estimate against measurement, compound 4: 1.5-fold (0.18 log units) above; the measured number falls inside the stated range.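

In the taste receptor type 2 member 8 assay the methoxy in place of hydrogen, here ortho to a large group, gives a 2.0-fold lower number from compound 3 to compound 4 (0.30 log units; within the scatter), and this step cannot be told apart from the one seen on the other core: the same change on two cores in the taste receptor type 2 member 8 assay, a 2.4-fold lower number (0.39 log units; beyond the scatter) from compound 1 to compound 2 and a 2.0-fold lower number (0.30 log units; within the scatter) from compound 3 to compound 4, 1.2-fold (0.08 log units) apart, within the scatter of two such steps This shows that, for these two pairs, the change keeps a similar size across the two cores, but it does not show a general rule, as the step on the core of compound 3 alone lies within the scatter and the methoxy does not stand in the same place in compound 2 and compound 4, so any effect of place cannot be separated from any effect of core. The change does not come without a difference elsewhere, as on the core of compound 3 it goes with lower solubility in a physicochemical assay for solubility, with a stated time of 24 h, at pH 7.1; on this read-out higher numbers stand for higher solubility and lower numbers for lower solubility: the measured solubility of compound 3, 70000 nM, and of compound 4, 16000 nM, a 4.4-fold lower number (0.64 log units; beyond the scatter) In the physicochemical assay compound 3 gives 70000 nM and compound 4 gives 16000 nM.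

The compounds shown leave open whether the same change on the core of compound 1 would go with a similar step in the physicochemical assay, and whether methoxy in another place on the same ring would keep the step seen in the taste receptor type 2 member 8 assay on either core. They also leave open how an amine, a carboxylic acid or a longer chain such as ethoxy, set on that ring in place of methoxy, would read in either the taste receptor type 2 member 8 assay or the physicochemical assay.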